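Shortening a side chain: from compound 2 toward compound 4

The compounds below may be only part of what the source reports. "The series", "measured", "known", "first", "only" and "open" are said of these compounds alone.

Measured so far:
compound 1 `CN1CCN(c2nc(Cl)nc3c2ncn3Cc2ccc(C(=O)Nc3ccccc3N)cc2)CC1` — 71.6%
compound 2 `COC(CCn1cnc2c(NCc3ccc(C(=O)Nc4ccccc4N)cc3)nc(Cl)nc21)OC` — 6.39%
compound 3 `CC(C)n1cnc2c(Nc3ccccc3)nc(NCOCc3ccc(/C=C/C(=O)Nc4ccccc4N)cc3)nc21` — 2.53%

In a functional assay on HCT-116 cells (Homo sapiens) for antiproliferative activity, read by CCK-8 assay, with a stated time of 72 h, tested at 2 uM (a higher number here means a stronger effect of the compound at the concentration tested, a lower number a weaker effect), compound 1 gives 71.6%, a strong effect. Compound 2 gives 6.39% and compound 3 gives 2.53%; these two lie within the scatter of each other, so no order between them can be read. Compound 2 therefore sits with compound 3 at the weak end, far below compound 1, whose gap to compound 2 is well beyond the scatter.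

Compound 4 `CCCn1cnc2c(NCc3ccc(C(=O)Nc4ccccc4N)cc3)nc(Cl)nc21` has not yet been measured in this assay. It keeps the whole core of compound 2 and changes only one spot: methyl in place of dimethoxymethyl on a saturated chain carbon, two bonds along the chain from an aromatic nitrogen. Going by the values given here, no pair of measured compounds differs in just one place, so nothing here shows how such a swap of a dimethoxymethyl for a methyl moves the read-out. Compound 1 and compound 3 differ from compound 2 in several places at once and cannot serve as a guide for this single change. The step from compound 2 to compound 4 is therefore expected to be small, with no clear direction, most likely within the scatter; the estimated step is a number 5.6 percentage points higher from compound 2 to compound 4 (within the scatter). Compound 4 is expected to give about 12%, in a range from 0% to 35%.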

Compound 4, a percentage reported as inhibition, at one concentration (the size of the read-out at that concentration, not a potency): 28.5%
Compound 4: the middle estimate sits 16.5 percentage points below what was measured; low and high end bracket the measured number.
By their numbers in this assay, from the lowest: compounds 3 and 2 (each within the scatter of the next); then compound 4; then compound 1.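

Going by these compounds alone, this is the first change in a single place that can be read here. In this assay, putting methyl in place of dimethoxymethyl on a saturated chain carbon, two bonds along the chain from an aromatic nitrogen, gives a number 22.1 percentage points higher from compound 2 to compound 4 (beyond the scatter). The read-out therefore responds to the end of this chain, as the step from 3,3-dimethoxypropyl to propyl lies beyond the usual scatter with the rest of the molecule unchanged. Nothing measured here says what lies behind this step.

Still open, as far as these compounds go, is how the read-out follows the chain end more generally: a chain ending in an amine or a carboxylic acid, or a longer chain such as butyl, could show whether the effect tracks the chain's length or the group at its end. From the compounds shown here alone, whether the same swap moves the read-out in the same direction on a different core also remains unknown.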